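The source may report more compounds than this note shows. Statements on the series, on what has been measured and on what is new or still open speak of the compounds shown alone.

In a functional assay on A549 cells (Homo sapiens) for inhibition, read by MTT assay; on this read-out lower numbers stand for stronger inhibition and higher numbers for weaker inhibition:
- compound 1 `CCCCCCCCCCCCCCCC(=O)OC1=C(CC=C(C)C)C(=O)c2ccccc2C1=O`: 38000 nM
- compound 2 `CCCCCCCCCCCCCCCCCC(=O)OC1=C(CC=C(C)C)C(=O)c2ccccc2C1=O`: > 100000 nM (a limit of the assay)

Compound 2 has no number on this scale, only the limit shown, so it offers a bound and not a fixed starting point. Compound 3 `CCCCCCCC/C=C\CCCCCCCC(=O)OC1=C(CC=C(C)C)C(=O)c2ccccc2C1=O` carries dec-1-en-1-yl in place of decyl on a saturated chain carbon, seven bonds along the chain from a carbonyl carbon. For the measured compounds named here, one measured step bears on this, and only indirectly: an at least 2.6-fold higher number from compound 1 to compound 2 (0.42 log units; beyond the scatter). That step lengthens the chain and does not test a double bond. A modest move to a lower number is expected, towards the range of compound 1 at 38000 nM. The expected change is an at least 1.8-fold lower number from compound 2 to compound 3 (0.25 log units; that floor lies within the scatter). For compound 3 the estimate is 55000 nM, with an expected range of 20000 nM to 100000 nM.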

Compound 3, half-maximal inhibitory concentration: 59000 nM
For compound 3 the middle estimate is 1.1-fold (0.03 log units) below the measured one, and the stated range covers the measured number.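

In this assay, dec-1-en-1-yl in place of decyl, on a saturated chain carbon seven bonds along the chain from a carbonyl carbon, gives an at least 1.6-fold lower number from compound 2 to compound 3 (0.22 log units; that floor lies within the scatter). Compound 2 is held only by a limit of the assay, so this step has a floor and no fixed size: the limit of > 100000 nM in this assay, at which 1 of the 3 values shown sits.

Dec-1-en-1-yl in place of octyl at the same place gives a 1.6-fold higher number from compound 1 to compound 3 (0.19 log units; within the scatter), which leaves compound 3 level with compound 1 and gives the series a second measured value among its long chains.

The compounds shown leave open how much of the step from the decyl chain belongs to the double bond, as the saturated partner offers no fixed value. Also open, on these data alone, is how the series reads with a terminal amine or a carboxylic acid on the chain, or with a shorter chain.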